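The compounds below may be only part of what the source reports. "The series", "measured", "known", "first", "only" and "open" are said of these compounds alone.

The study gathers two measured compounds and one still to be tested, all built on one shared core carrying a stilbene-like arm and an amide linker to a second double-bonded chain. In a functional assay on HT-29 cells (Homo sapiens) for inhibition, read by MTT assay, with a stated time of 48 h (on this read-out lower numbers stand for stronger inhibition and higher numbers for weaker inhibition), compound 1 `COc1cc(/C=C/c2ccc(NC(=O)/C=C/c3cc(OC)c(OC)c(OC)c3)cc2)cc(OC)c1` gives 1820 nM. In this assay compound 2 `COc1cc(/C=C/c2ccc(NC(=O)/C=C/c3ccc(C#N)cc3)cc2)cc(OC)c1` gives 3320 nM. Compound 2 is the only other number shown, and its value and that of compound 1 lie within the usual scatter of each other, so neither compound can be set apart from the other on these data.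

Compound 3 `COc1cc(/C=C/c2ccc(NC(=O)/C=C/c3ccc(F)cc3F)cc2)cc(OC)c1` is the untested member. It differs from compound 2 in one place: 2,4-difluorophenyl in place of 4-cyanophenyl on a double-bonded chain carbon bound to a double-bonded chain carbon. Within the data shown here, no pair of measured compounds shares this kind of change, so no measured step can be borrowed. Among the measured compounds shown here, the two values so far sit close together, and the change is a swap of one substituted aromatic ring for another of equal size at the far end of the chain. The step from compound 2 to compound 3 in this assay is therefore expected to be small, a 1.3-fold lower number from compound 2 to compound 3 (0.11 log units; within the scatter), with no direction favoured beyond the scatter. Compound 3 is estimated at 2600 nM in this assay, within a range from 1000 nM to 7000 nM.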

Compound 3, half-maximal inhibitory concentration: 18100 nM
Compound 3: the middle estimate sits 7.0-fold (0.84 log units) below what was measured; the measured number lies above the stated range.
By their numbers in this assay, from the lowest: compounds 1 and 2 (each within the scatter of the next); then compound 3.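

The swap gives a 5.5-fold higher number from compound 2 to compound 3 (0.74 log units; beyond the scatter) in this assay, the only step shown at this position and one that lies beyond the scatter. Compound 1 and compound 2 alone, with values within the scatter of each other, could not show that the aromatic ring on this double-bonded chain carbon can change the read-out. Since 4-cyanophenyl and 2,4-difluorophenyl have the same heavy-atom count and each is one six-membered aromatic ring of carbon only, the step shows that keeping these counts does not keep the number within the scatter, although nothing shown gives a measured reason for the step.

The single change removes the nitrile and adds two fluorines at once, so the compounds shown leave open whether the higher number goes with the loss of the nitrile, the presence of the fluorines, or both. On these data alone, an unsubstituted phenyl ring, a phenyl ring carrying a single fluorine or a carboxylic acid on the ring at this place would be needed to separate these readings, and how far the step holds on other versions of the shared core also stays open.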